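Side-chain swap on compound 1: hydantoin to triazole

The source may hold more compounds than are shown below. What is called first, only, known or untested is meant among the compounds shown, and "the series" means these compounds.

Within the data shown here, compound 1 `CCO/C(O)=C1\C(COCCN2CC(=O)NC2=O)=NC(C)=C(C(=O)OC)C1c1ccccc1Cl` gives 20 nM in a functional assay (aorta) with Rattus norvegicus as the target (on this read-out higher numbers stand for weaker inhibition and lower numbers for stronger inhibition), the higher of the two numbers measured so far; compound 2 `CCO/C(O)=C1\C(COCCN2CC(=O)NC2=O)=NC(C)=C(C(=O)OC)C1c1cccc(Cl)c1Cl` gives 3.16 nM. Among the measured compounds shown here, the single measured step, a 6.3-fold lower number from compound 1 to compound 2 (0.80 log units; beyond the scatter), concerns a chloro in place of hydrogen on an aromatic carbon and leaves the side chain untouched. Compound 3 `CCO/C(O)=C1\C(COCCn2ccnn2)=NC(C)=C(C(=O)OC)C1c1ccccc1Cl` differs from compound 1 elsewhere: 1H-1,2,3-triazol-1-yl in place of 2,4-dioxoimidazolidin-1-yl on a saturated chain carbon, two bonds along the chain from an oxygen on a saturated carbon. The ethoxy link stays; the ring at its end changes from a non-aromatic to an aromatic one. For the measured compounds named here, no measured pair varies this ring, so nothing seen so far bears on the size or direction of the step in this assay. Compound 3 is therefore expected to sit near compound 1, with no change at the digits printed from compound 1 to compound 3 (within the scatter) and a wide margin of uncertainty. Compound 3 is estimated at 20 nM, within 5 nM to 80 nM.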

Compound 3, half-maximal inhibitory concentration: 15.9 nM
Compound 3: middle estimate off by 1.3-fold (0.10 log units), on the high side, within the range that was stated.
By their numbers in this assay, from the lowest: compound 2; then compounds 3 and 1 (each within the scatter of the next).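

In this assay, the exchange at this saturated chain carbon gives a 1.3-fold lower number from compound 1 to compound 3 (0.10 log units; within the scatter), so this read-out does not separate 2-(1H-1,2,3-triazol-1-yl)ethoxy from 2-(2,4-dioxoimidazolidin-1-yl)ethoxy. For this pair, the read-out stays within the scatter even though the non-aromatic ring gives way to an aromatic one and the hydrogen-bond donor count goes from 1 to 0, so neither the donor nor the non-aromatic ring is needed to hold the value of compound 1. No measurement at hand offers an explanation for this result.

As far as these compounds go, it remains open whether the chloro step, a 6.3-fold lower number from compound 1 to compound 2 (0.80 log units; beyond the scatter), carries over when 1H-1,2,3-triazol-1-yl is present. From the compounds shown here alone, it is also open how a primary amine, a carboxylic acid or a longer chain carrying the triazole would read at this position.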